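The source may hold more compounds than are shown below. What is called first, only, known or untested is meant among the compounds shown, and "the series" means these compounds.

Measured compounds:
- compound 1, `CCCn1c(=O)n(C)c(=O)c2[nH]c(-c3ccccc3)nc21`, with 6.3 nM in an assay on Cortex for displacement of a labelled ligand from adenosine receptor A1 (Rattus norvegicus); on this read-out lower numbers stand for stronger inhibition and higher numbers for weaker inhibition
- compound 2, `CCCn1c(=O)n(C)c(=O)c2[nH]c(-c3cccs3)nc21`, with 8.93 nM in this assay

Compound 2 gives the highest of the two numbers in this assay, yet its nearest neighbour is compound 1 and the step of a 1.4-fold higher number from compound 1 to compound 2 (0.15 log units; within the scatter) stays within the scatter, so the two compounds cannot be told apart on this read-out. Compound 3, `CCCn1c(=O)n(C)c(=O)c2[nH]c(-c3ccncc3)nc21`, has not been measured. It differs from compound 2 in one place: pyridin-4-yl in place of thiophen-2-yl on an aromatic carbon. Among the measured compounds shown here, only one measured step bears on this change, namely the exchange of one aromatic ring for another on the same carbon of the shared core, a 1.4-fold higher number from compound 1 to compound 2 (0.15 log units; within the scatter), and that step lay within the scatter. Nothing measured speaks to a six-membered ring with a nitrogen at that position, so the reach of the data is short. On this basis the step from compound 2 to compound 3 is expected to be modest, most likely a somewhat higher number, a 1.7-fold higher number from compound 2 to compound 3 (0.23 log units; within the scatter). Compound 3 is therefore estimated at 15 nM in this assay, with a range from 5 nM to 60 nM.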

Compound 3, inhibition constant: 21.8 nM
Estimate against measurement, compound 3: 1.5-fold (0.16 log units) below; the measured number falls inside the stated range.
By their numbers in this assay, from the lowest: compounds 1 and 2 (each within the scatter of the next); then compound 3.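

At this position, on the aromatic carbon between two ring nitrogen atoms, exchanging one aromatic ring for another now moves the number in this assay beyond the scatter: pyridin-4-yl in place of thiophen-2-yl gives a 2.4-fold higher number from compound 2 to compound 3 (0.39 log units; beyond the scatter), and pyridin-4-yl in place of phenyl gives a 3.5-fold higher number from compound 1 to compound 3 (0.54 log units; beyond the scatter). The second step keeps a six-membered aromatic ring, so the shift also appears when a ring nitrogen enters without a change in ring size, something the earlier pair, which could not be told apart, did not reveal. Both steps are modest, however, and no measurement here accounts for the shift.

The compounds shown leave open whether the position responds more strongly to a saturated ring such as cyclohexyl, or to an amine or a carboxylic acid carried on the phenyl ring. They also leave open whether the same ring exchange would give similar steps with a longer chain in place of the propyl group on the shared core.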